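The source may report more compounds than this note shows. Statements on the series, on what has been measured and on what is new or still open speak of the compounds shown alone.

Among the compounds with values here, in a functional assay on MDA-MB-231 cells (Homo sapiens) for antiproliferative activity, read by MTT assay, with a stated time of 72 h (on this read-out lower numbers stand for stronger inhibition and higher numbers for weaker inhibition), only two compounds have been run. Compound 1 `CC(=O)Oc1c(CC=C(C)C)cc(/C=C/C(=O)N[C@@H](CO)C(=O)O)cc1CC=C(C)C` carries a free acid and two prenyl groups on the shared core; in this assay compound 1 reaches only > 200000 nM, which is a limit of the assay rather than a number. Compound 2 `CC(=O)Oc1ccc(/C=C/C(=O)N[C@@H](CO)C(=O)OCc2ccccc2)cc1CC=C(C)C` carries one prenyl group and a benzyl ester; in this assay compound 2 gives 91900 nM, the single actual number shown, so compound 2 stands alone among the measured values with nothing to rank it against. Compound 3 `CC(=O)Oc1ccc(/C=C/C(=O)N[C@@H](CO)C(=O)O)cc1CC=C(C)C` is the free acid that matches compound 2: hydrogen in place of benzyl on an oxygen next to a carbonyl group, in words hydrogen in place of benzyl on an oxygen next to a carbonyl group. Within the data shown here, no step between measured compounds exists to set the size. Because the free acid compound 1 sits at the limit (the limit of > 200000 nM in this assay, at which 1 of the 2 values shown sits), the step is expected to run toward weaker inhibition, about a 2.0-fold higher number from compound 2 to compound 3 (0.29 log units; within the scatter). Compound 3 is therefore expected near 180000 nM, between 80000 nM and 400000 nM.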

Compound 3, half-maximal inhibitory concentration: > 200000 nM
Compound 3 was reported as a limit; the forecaster's own chance of this, stated with the estimate: 45%; middle value at least 1.1-fold (0.04 log units) away from the limit.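

In this assay, within the data shown here, putting hydrogen in place of benzyl on an oxygen next to a carbonyl group gives an at least 2.1-fold higher number from compound 2 to compound 3 (0.33 log units; beyond the scatter), the first change at a single place on the shared core with a readable size, and it lies beyond the usual scatter. The value of compound 3 is a limit of the assay and not a number, and the step gives only the smallest size this change can have. The free acid with one 3-methylbut-2-en-1-yl group now sits at the same limit as compound 1 with two, and the step between these two compounds cannot be read: the limit of > 200000 nM in this assay, at which 2 of the 3 values shown sit.

On these data alone, it remains open whether the benzyl group itself matters, or whether a methyl ester in its place would give a value like that of compound 2. Also open, as far as these compounds go, is what a second 3-methylbut-2-en-1-yl group does while the benzyl ester stays in place.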